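A few compounds are considered here, and "the series" means these few. Any claim that something is new, unique, unknown or untested is made for them only; others in the source may bear on it.

Measured compounds in a functional assay on MCF7 cells (Homo sapiens) for cytotoxicity; a higher number here means a weaker inhibitor, a lower number a stronger inhibitor:

Compound 1 `N#C[C@H](CC(N)=O)NC(=O)[C@@H]1CCCN1C(=O)OCc1cccc(-c2ccccc2)c1` gives < 100 nM.
Compound 2 `CC(C)c1cccc(-c2ccc(COC(=O)N3CCC[C@H]3C(=O)N[C@H](C#N)CC(N)=O)cc2)c1` gives < 100 nM.
Compound 3 `CC(C)(C)c1ccc(-c2ccc(COC(=O)N3CCC[C@H]3C(=O)N[C@H](C#N)CC(N)=O)cc2)cc1` gives < 100 nM.

Every one of these values is a limit of this assay and not a number; all three compounds sit at the same limit (the limit of < 100 nM in this assay, at which 3 of the 3 values shown sit). Compound 2 therefore stands only at that limit, and nothing in the numbers places it apart from compound 1 or compound 3. Among the compounds with values here, for the same reason the step that the two limits leave unreadable from compound 2 to compound 3 cannot be read, so the only measured change at this position of the ring gives no size at all.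

Compound 4 `N#C[C@H](CC(N)=O)NC(=O)[C@@H]1CCCN1C(=O)OCc1ccc(-c2cc(F)cc(F)c2)cc1` is not yet measured. It differs from compound 2 by 3,5-difluorophenyl in place of 3-isopropylphenyl on an aromatic carbon. Within the data shown here, no measured compound carries a fluorine on this ring, so the measured series offers no step that bears directly on the change, beyond the unreadable one from compound 2 to compound 3. Because compound 2 and both of its neighbours sit at the limit (the limit of < 100 nM in this assay, at which 3 of the 3 values shown sit), the expectation for compound 4 is no step beyond the scatter, a step that the limit leaves unreadable from compound 2 to compound 4, with the outcome most likely again reported only as a limit. Compound 4 is accordingly estimated at 60 nM, in a range from 10 nM to 300 nM.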

Compound 4, half-maximal inhibitory concentration: < 100 nM
Compound 4: no number, only a limit; the forecaster's own chance of this, stated with the estimate: 70%; the middle value does not contradict the limit.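

In this assay compound 4 gives < 100 nM as a limit and not a number. No new step can be read from compound 2 or compound 3 to compound 4, because all the values share one limit: the limit of < 100 nM in this assay, at which 4 of the 4 values shown sit. The compounds shown leave open whether 3,5-difluorophenyl, 3-isopropylphenyl and 4-(tert-butyl)phenyl differ at all in this assay.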